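The source may report more compounds than this note shows. Statements on the series, on what has been measured and on what is new or still open speak of the compounds shown alone.

Compound 1 `CC(O)c1cccc(C(=O)N[C@@H](C)Cn2ccc(-c3ccc(C#N)c(Cl)c3)n2)c1` and compound 2 `CC(=O)c1ccc(C(=O)N[C@@H](C)Cn2ccc(-c3ccc(C#N)c(Cl)c3)n2)cc1` share one core and differ only in the aryl group on the amide carbonyl. In a functional assay on LNCaP cells (Homo sapiens) for antiproliferative activity, read by CCK-8 assay, with a stated time of 6 days (on this read-out lower numbers stand for stronger inhibition and higher numbers for weaker inhibition), compound 1 gives 2280 nM, and compound 2 gives 3600 nM. The step of a 1.6-fold higher number from compound 1 to compound 2 (0.20 log units; within the scatter) lies within the scatter. Going by the values given here, of the two numbers, that of compound 2 is the larger, yet since its only neighbour, compound 1, sits within the scatter of it, the two cannot be ranked.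

Compound 3 `COc1ccc(C(=O)N[C@@H](C)Cn2ccc(-c3ccc(C#N)c(Cl)c3)n2)cc1` follows from compound 2 by methoxy in place of acetyl on an aromatic carbon. Among the compounds with values here, the single measured step that bears on the amide aryl group is a 1.6-fold higher number from compound 1 to compound 2 (0.20 log units; within the scatter), a different exchange and one that stayed within the scatter. Within the data shown here, no measured pair trades an acetyl for a methoxy, so the data give no direction for this change. The expectation is therefore a step of a 1.2-fold lower number from compound 2 to compound 3 (0.08 log units; within the scatter) in this assay that does not exceed the scatter, with no firm direction. On that basis compound 3 is estimated at 3000 nM, with a range from 1200 nM to 9000 nM.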

Compound 3, half-maximal inhibitory concentration: 3410 nM
The estimate for compound 3 lay 1.1-fold (0.06 log units) below the measured number; measured number inside the range.
By their numbers in this assay, from the lowest: compounds 1, 3 and 2 (each within the scatter of the next).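

In this assay, methoxy in place of acetyl on the aromatic carbon para to a large group gives a 1.1-fold lower number from compound 2 to compound 3 (0.02 log units; within the scatter), so this position has now carried two different groups without the two compounds being separable. The second new step, a 1.5-fold higher number from compound 1 to compound 3 (0.17 log units; within the scatter), also stays within the scatter, which places all three aryl groups on the amide carbonyl, 3-(1-hydroxyethyl)phenyl, 4-acetylphenyl and 4-methoxyphenyl, within the scatter of one another, and none of them stands apart from the others. Nothing among the available data offers an explanation for this lack of separation.

The compounds shown leave open whether any group at this position can move the number beyond the scatter, for instance an amine, a carboxylic acid or a longer alkoxy chain in place of methoxy. They also leave open whether the aryl group on the amide carbonyl is needed at all, since every compound here carries one and none has a simple alkyl chain there instead.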